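Swapping the Amine Ring at the Chain End

The source may hold more compounds than are shown below. What is called first, only, known or untested is meant among the compounds shown, and "the series" means these compounds.

Three compounds built on one shared core were tested in a functional assay on HT-29 cells (Homo sapiens) for inhibition, read by MTT assay, with a stated time of 72 h; on this read-out higher numbers stand for weaker inhibition and lower numbers for stronger inhibition. Compound 1 `COc1cc2c(Oc3ccc(NC(=O)c4nn(-c5ccccc5)c(=O)cc4C)cc3F)ccnc2cc1OCCCN1CCCCC1` gives 160 nM. Compound 2 `COc1cc2c(Oc3ccc(NC(=O)c4nn(-c5ccccc5C)c(=O)cc4C)cc3F)ccnc2cc1OCCCN1CCCCC1` gives 2810 nM; the step of an 18-fold higher number from compound 1 to compound 2 (1.24 log units; beyond the scatter) comes from a single methyl added on an aromatic carbon. Compound 3 `COc1cc2c(Oc3ccc(NC(=O)c4nn(-c5ccc(Cl)cc5)c(=O)cc4C)cc3F)ccnc2cc1OCCCN1CCCC1` gives 260 nM, the second-highest of the three numbers: it lies within the scatter of compound 1 and well below compound 2, beyond the scatter.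

Compound 4 `COc1cc2c(Oc3ccc(NC(=O)c4nn(-c5ccc(Cl)cc5)c(=O)cc4C)cc3F)ccnc2cc1OCCCN1CCCCC1` has not been measured. It differs from compound 3 only at the chain end: piperidin-1-yl in place of pyrrolidin-1-yl on a saturated chain carbon, three bonds along the chain from an oxygen on an aromatic ring.

Going by the values given here, no measured step isolates this change. Among the compounds with values here, the one single-point step, from compound 1 to compound 2, concerns a methyl on an aromatic carbon and says nothing about the chain end. Compound 1 carries the piperidin-1-yl end and compound 3 the pyrrolidin-1-yl end, but they also differ by a chlorine on the phenyl, and their two values fall within the scatter of each other. On this basis the step of a 1.2-fold lower number from compound 3 to compound 4 (0.07 log units; within the scatter) is expected to stay within the scatter. Compound 4 is therefore estimated at 220 nM, with a likely range from 90 nM to 550 nM in this assay.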

Compound 4, half-maximal inhibitory concentration: 360 nM
For compound 4 the middle estimate is 1.6-fold (0.21 log units) below the measured one; the range from low to high includes it.
By their numbers in this assay, from the lowest: compounds 1, 3 and 4 (each within the scatter of the next, the first and the last beyond it); then compound 2.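

In this assay, going by these compounds alone, the swap at the chain end now stands alone for the first time: the measured step is a 1.4-fold higher number from compound 3 to compound 4 (0.14 log units; within the scatter) and so, with a 4-chlorophenyl on the aromatic nitrogen, the pyrrolidin-1-yl and piperidin-1-yl ends cannot be told apart at this position. With the piperidin-1-yl end held fixed, the new compound also gives two readable steps at the other end of the molecule: chloro in place of hydrogen gives a 2.3-fold higher number from compound 1 to compound 4 (0.35 log units; beyond the scatter) and 4-chlorophenyl in place of 2-methylphenyl gives a 7.8-fold lower number from compound 2 to compound 4 (0.89 log units; beyond the scatter) and, unlike the amine swap, both lie beyond the scatter. Nothing at hand explains any of these steps.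

On these data alone, whether the two amine rings stay interchangeable with a plain phenyl or a 2-methylphenyl on the aromatic nitrogen remains open, since the swap is seen with the 4-chlorophenyl only. As far as these compounds go, it is also open how a morpholine ring, an open-chain dimethylamino group or a shorter 2-(piperidin-1-yl)ethyl chain would read at this position.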